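Chloro substitution on the distal aryl ring

This account rests on a few compounds, and the source may have more. Where it says the series, first, only, none or still open, it means among the compounds named here.

Measured so far in an assay on HEK293 cells for displacement of a labelled ligand from D(4) dopamine receptor (Homo sapiens), read by scintillation counting, with a stated time of 60 min; a higher number here means a weaker inhibitor, a lower number a stronger inhibitor:
compound 1 `CCc1cccc(NC(=O)CN2CCN(c3ccccn3)CC2)c1`: 67.9 nM
compound 2 `Cc1cccc(NC(=O)CN2CCC(c3ccccc3)CC2)c1`: 25.8 nM
compound 3 `CCc1cccc(NC(=O)CN2CCN(c3ccc(Cl)cn3)CC2)c1`: 172 nM

Compound 2 gives the lowest number of the three. The difference between the core of compound 1 and the core of compound 2 is not broken down here. From compound 1 to compound 3 the change is chloro in place of hydrogen on an aromatic carbon; it gave a 2.5-fold higher number from compound 1 to compound 3 (0.40 log units; beyond the scatter). Compound 4 `Cc1cccc(NC(=O)CN2CCC(c3ccc(Cl)cc3)CC2)c1` is not yet measured and carries the same kind of change against compound 2, (chloro in place of hydrogen on an aromatic carbon), but the place differs: in compound 3 the chloro sits on a six-membered aromatic ring with 1 nitrogen, two atoms from the ring nitrogen, whereas in compound 4 it sits on a six-membered aromatic ring of carbon only. For the measured compounds named here, because the only comparable step measured is a 2.5-fold higher number from compound 1 to compound 3 (0.40 log units; beyond the scatter), a step of similar size and direction is expected, a 2.1-fold higher number from compound 2 to compound 4 (0.33 log units; beyond the scatter). Compound 4 is thus estimated at 55 nM, with a range from 25 nM to 130 nM.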

Compound 4, inhibition constant: 115 nM
Beside the measured number, compound 4's estimate is 2.1-fold (0.32 log units) below it, and the stated range covers the measured number.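

Chloro in place of hydrogen on an aromatic carbon again weakens binding in this assay, and the new step gives a 4.5-fold higher number from compound 2 to compound 4 (0.65 log units; beyond the scatter). Set beside the earlier step, the change carries over between the two cores in direction, and its size does not separate them: the same change on two cores in this assay, a 2.5-fold higher number (0.40 log units; beyond the scatter) from compound 1 to compound 3 and a 4.5-fold higher number (0.65 log units; beyond the scatter) from compound 2 to compound 4, 1.8-fold (0.25 log units) apart, within the scatter of two such steps. For the compounds shown here, this is only one pair of steps, so it does not show that the change would carry over to other cores or to other places on the ring, and it does not show why the number rises.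

Going by these compounds, whether fluoro, methoxy or nitrile in the same place would move the number the same way remains open. On these data alone, the outcome with an amine or a carboxylic acid there is also open.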